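The source may hold more compounds than are shown below. What is called first, only, known or untested is meant among the compounds shown, and "the series" means these compounds.

Measured compounds:
- compound 1 `O=C(Nc1cccc(-n2cc(-c3ccncc3)c(-c3cc(O)cc(Cl)c3)n2)c1)Nc1ccc(Cl)c(C(F)(F)F)c1`, in a functional assay on HCC 2998 cells (Homo sapiens) for inhibition, read by sulforhodamine B assay, with a stated time of 48 h, tested at 100 uM (on this read-out lower numbers stand for a stronger effect and higher numbers for a weaker effect at the one concentration tested), compound 1 gives -88%
- compound 2 `COc1cc(Cl)cc(-c2nn(-c3cccc(NC(=O)Nc4cc(C(F)(F)F)cc(C(F)(F)F)c4)c3)cc2-c2ccncc2)c1`, in this assay compound 2 gives -70%

Both measured compounds share the same core and differ in the substitution pattern on the aryl urea and on the chlorophenol side. Of the two numbers shown, compound 2 has the higher one; compound 1 sits lower, a gap beyond the usual scatter, so compound 1 shows the stronger effect at the single concentration tested.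

Compound 3 `COc1cc(Cl)cc(-c2nn(-c3cccc(NC(=O)Nc4cccc(C(F)(F)F)c4)c3)cc2-c2ccncc2)c1` is not yet measured in this assay. Compared with compound 2 the change is hydrogen in place of trifluoromethyl on an aromatic carbon.

Among the compounds with values here, no step between measured compounds isolates this change, so the direction must rest on the two values alone. Compound 2 already carries the higher of the two numbers, and losing one of its two trifluoromethyl groups is expected to leave the effect similar or somewhat weaker. The expected step from compound 2 to compound 3 is a number 15 percentage points higher from compound 2 to compound 3 (beyond the scatter), most likely a modest move toward a higher number, possibly within the scatter. Compound 3 is therefore estimated at -55%, with a plausible range from -85% to -15%.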

Compound 3, a percentage reported as activity, at one concentration (the size of the read-out at that concentration, not a potency): -83%
Compound 3: the middle estimate sits 28 percentage points above what was measured; the range from low to high includes it.
By their numbers in this assay, from the lowest: compounds 1 and 3 (each within the scatter of the next); then compound 2.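

In this assay, hydrogen in place of trifluoromethyl on this aromatic carbon gives a number 13 percentage points lower from compound 2 to compound 3 (beyond the scatter) and so moves the read-out toward a stronger effect at the one concentration tested. Within the data shown here, this is the first comparison that isolates a single place, and it shows that the second trifluoromethyl group of compound 2 is not required for the effect in this read-out, since compound 3 keeps a strong effect with only one trifluoromethyl group on that ring. The data shown offer no measurement that accounts for the size or direction of this step.

The compounds shown leave open how this aromatic carbon responds to groups other than hydrogen and trifluoromethyl, such as an amine or a carboxylic acid, and whether the remaining trifluoromethyl group can also give way to hydrogen without loss of effect. With one concentration per compound, they also leave open whether the order of compound 2 and compound 3 would hold at lower concentrations or in other cell lines.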